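The source may hold more compounds than are shown below. What is called first, only, known or untested is meant among the compounds shown, and "the series" means these compounds.

compound 1 (`O=C(/C=C/c1ccc(C(F)(F)F)cc1)c1ccc(O)cc1O`) – "not determined" (no result reported)
compound 2 (`O=C(/C=C/c1ccc(OCc2ccccc2)cc1)c1ccc(O)cc1O`) – 10500 nM
compound 3 (`COc1ccc(/C=C/C(=O)c2ccc(O)cc2O)cc1`) – "not determined" (no result reported)

These three compounds were examined in a functional assay on NCI-H460 cells (Homo sapiens) for inhibition, read by sulforhodamine B assay, with a stated time of 48 h (a higher number here means a weaker inhibitor of growth, a lower number a stronger inhibitor of growth), and differ in the group on one ring. Only compound 2 carries a number. Compound 1 stands without a single number: its entry reads ("not determined" (no result reported)), and the entry of compound 3 reads the same ("not determined" (no result reported)). Within the data shown here, no step between measured compounds can therefore be read.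

Compound 4 (`Cc1c(O)ccc(C(=O)/C=C/c2ccc(C(F)(F)F)cc2)c1O`) is compound 1 with one change (methyl in place of hydrogen on an aromatic carbon): methyl in place of hydrogen on an aromatic carbon, ortho to two hydroxy groups and meta to a large group. With no number for compound 1, the size of this step cannot be taken from the data. A small step toward stronger inhibition of growth is expected, hardly beyond the scatter. Among the measured compounds shown here, the only anchor is compound 2 (10500 nM), so compound 4 is expected in the same region, with a wide margin. The estimated value for compound 4 is 12000 nM, with an expected range from 3000 nM to 40000 nM.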

Compound 4, concentration for 50% growth inhibition: 20300 nM
Estimate against measurement, compound 4: 1.7-fold (0.23 log units) below; low and high end bracket the measured number.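

Among these compounds, no step from compound 1 to compound 4 can be read, as compound 1 carries no number to set against that of compound 4. The compounds shown leave open what the added methyl changes in growth inhibition. No measured property bears on this result.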